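The compounds below may be only part of what the source reports. "The series", "measured", "known", "first", "only" and "open" are said of these compounds alone.

Measured so far in a physicochemical assay for lipophilicity; on this read-out lower numbers stand for lower lipophilicity and higher numbers for higher lipophilicity: compound 1 `COC(=O)/C=C(C)/C=C/CC(C)CCCC(C)C` gives 6.2; compound 2 `CCC(C)OC(=O)/C=C(C)/C=C/CC(C)CCCC(C)(C)OC` gives 6.49; compound 3 `COC(C)(C)CCCC(C)C/C=C/C(C)=C/C(=O)OC1CC1` gives 5.71.

Compound 3 stands lowest of the three in this assay; compound 1 lies nearest and compound 2 furthest, both beyond the scatter. Compound 4 `CCNC(=O)/C=C(C)/C=C/CC(C)CCCC(C)(C)OC` differs from compound 3 at one place: ethylamino in place of cyclopropyloxy on a carbonyl carbon. Among the compounds with values here, the only measured single-place step, a number 0.78 log units lower from compound 2 to compound 3 (beyond the scatter), exchanges one group on an oxygen next to a carbonyl group for another and leaves that oxygen in place, whereas the change to compound 4 removes it. Within the data shown here, no measured pair bears directly on this change, so the expectation rests on the structural change alone. Compound 4 is expected to lie lower, the estimated step being a number 1.21 log units lower from compound 3 to compound 4 (beyond the scatter). In this assay compound 4 is estimated at 4.5, within a range from 3.9 to 5.2.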

Compound 4, partition coefficient: 4.04
Beside the measured number, compound 4's estimate is 0.46 log units above it, and the stated range covers the measured number.
By their numbers in this assay, from the lowest: compound 4; then compound 3; then compounds 1 and 2 (each within the scatter of the next).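

In this assay, the earlier step only exchanged one group on the oxygen, whereas replacing that oxygen-linked group with ethylamino on the carbonyl carbon gives a number 1.67 log units lower from compound 3 to compound 4 (beyond the scatter) and a number 2.45 log units lower from compound 2 to compound 4 (beyond the scatter). Both steps are large, and each ends at compound 4, which carries the hydrogen-bond donor that cyclopropyloxy lacks. Nothing shown here accounts for these steps.

The compounds shown leave open where cyclopropylamino or sec-butylamino would stand on this carbonyl carbon, which would separate the effect of the nitrogen from that of its ethyl group. From the compounds shown here alone, a carboxylic acid at this place also remains open.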